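Phenoxy for Piperidinyl on a Sulfonyl Sulfur

A few compounds are considered here, and "the series" means these few. Any claim that something is new, unique, unknown or untested is made for them only; others in the source may bear on it.

The study follows inhibition in an assay on liver for inhibition of sterol O-acyltransferase 1 (Rattus norvegicus), using microsomes (on this read-out higher numbers stand for weaker inhibition and lower numbers for stronger inhibition), through a pair of carbamates built on a shared core. Compound 1 `CC(C)c1cccc(C(C)C)c1OC(=O)NS(=O)(=O)N1CCCCC1` carries a piperidin-1-yl group on its sulfonyl sulfur. In this assay compound 1 gives > 100000 nM, which is a limit of the assay and not a number; compound 1 therefore stands at the limit of > 100000 nM in this assay, at which 1 of the 2 values shown sits. Among the compounds with values here, compound 2 `CCCCCCCCN(C)S(=O)(=O)NC(=O)Oc1c(C(C)(C)C)cc(C)cc1C(C)(C)C` is the only compound with a number in this assay, where compound 2 gives 18000 nM. Compound 3 `CC(C)c1cccc(C(C)C)c1OC(=O)NS(=O)(=O)Oc1ccccc1` differs from compound 1 in one place: phenoxy in place of piperidin-1-yl on a sulfonyl sulfur. Within the data shown here, no measured pair shows what this change does, so the expectation rests on compound 1 sitting at its limit. Among the measured compounds shown here, it also rests on compound 2, which gives 18000 nM as the sole real number in this assay. The step from compound 1 to compound 3 is expected to be an at least 1.6-fold lower number from compound 1 to compound 3 (0.22 log units; that floor lies within the scatter), toward stronger inhibition, but with a fair chance that only a limit is returned again. Compound 3 is estimated at 60000 nM in this assay, within a range from 15000 nM to 200000 nM.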

Compound 3, half-maximal inhibitory concentration: > 50000 nM
Compound 3 was reported as a limit (the forecaster's own chance of this, stated with the estimate: 55%); the middle value lies beyond the limit too.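

In this assay compound 3 gives > 50000 nM, which is a limit of the assay and not a number. Within the data shown here, compound 1 also stands at a limit, with > 100000 nM, so no step from compound 1 to compound 3 can be read. The compounds shown leave open whether phenoxy in place of piperidin-1-yl on a sulfonyl sulfur changes inhibition at all, and in which direction.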